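The compounds below may be only part of what the source reports. "The series", "measured", "known", "first", "only" and "open" are said of these compounds alone.

Among the compounds with values here, only two compounds with this shared core have been measured so far in a functional assay on A549 cells (Homo sapiens) for antiproliferative activity, read by MTT assay, with a stated time of 48 h; on this read-out lower numbers stand for stronger inhibition and higher numbers for weaker inhibition. Compound 1 (`COc1ccc(/C=C/c2cc(OC)cc(OC)c2/C=C/C(=O)c2ccc(Cl)c(Cl)c2)cc1`), with 3,4-dichlorophenyl on the carbonyl carbon, gives 5.9 ug/mL. Compound 2 (`COc1ccc(/C=C/c2cc(OC)cc(OC)c2/C=C/C(=O)c2ccc(C)cc2C)cc1`), with 2,4-dimethylphenyl there, gives 0.3 ug/mL, the lower of the two numbers. Compound 3 (`CCN(CC)c1ccc(C(=O)/C=C/c2c(/C=C/c3ccc(OC)cc3)cc(OC)cc2OC)cc1`) has not yet been measured. It keeps the rest of compound 2 and changes only the group on the carbonyl carbon, with 4-(diethylamino)phenyl in place of 2,4-dimethylphenyl on a carbonyl carbon.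

Within the data shown here, one measured step bears on this change, a 20-fold lower number from compound 1 to compound 2 (1.29 log units; beyond the scatter). It is large, well beyond the scatter, and it was made at the same carbonyl carbon, so a sizeable move is plausible here too. Neither measured compound carries the incoming group, however, so the data give no direct guide to its effect. Among the measured compounds shown here, a rise is the more likely outcome because compound 2 holds the lowest number so far at 0.3 ug/mL. The expected change is a 5.0-fold higher number from compound 2 to compound 3 (0.70 log units; beyond the scatter), towards weaker inhibition, though with wide uncertainty. For compound 3 the estimated value is 1.5 ug/mL, within an expected range of 0.3 ug/mL to 8 ug/mL.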

Compound 3, half-maximal inhibitory concentration: 5.4 ug/mL
Compound 3: middle estimate off by 3.6-fold (0.56 log units), on the low side; measured number inside the range.
By their numbers in this assay, from the lowest: compound 2; then compounds 3 and 1 (each within the scatter of the next).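

In this assay a second change on the carbonyl carbon gives an 18-fold higher number from compound 2 to compound 3 (1.26 log units; beyond the scatter) and so shows that compound 2 is not simply one of many low values at this position: leaving 2,4-dimethylphenyl has now cost a large step with two quite different incoming groups. Those two groups, 4-(diethylamino)phenyl and 3,4-dichlorophenyl, share little in their atoms, yet they end up level, with a 1.1-fold lower number from compound 1 to compound 3 (0.04 log units; within the scatter) and so no real difference between them. Among these three compounds, then, only the one with 2,4-dimethylphenyl stands apart, and no measurement here explains what sets that group apart from the other two.

Going by these compounds, what stays open is whether the low number of compound 2 goes with both methyl groups together or would survive with less, which a plain phenyl ring or a phenyl carrying a single methyl group on the carbonyl carbon would begin to answer. On these data alone, it is equally open whether other groups on the ring, such as methoxy or dimethylamino, would sit with compound 2 or with the other two compounds.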